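Acetyl on the Ring Amine Across Two Different Cores

A few compounds are considered here, and "the series" means these few. Any claim that something is new, unique, unknown or untested is made for them only; others in the source may bear on it.

Compound 1 `CCn1c(SCc2ccccc2)nc(N)c(N(Cc2ccccc2)Cc2ccccc2)c1=O` gives 450 nM in a functional assay on cardiac atrium (Cavia porcellus); on this read-out lower numbers stand for an effect already at smaller amounts and higher numbers for an effect only at larger amounts of compound.
Compound 2 `CCCSc1nc(N)c(N(CCC)CCC)c(OCC)n1` gives 150 nM in this assay.
Compound 3 `CCn1c(SCc2ccccc2)nc(NC(C)=O)c(N(Cc2ccccc2)Cc2ccccc2)c1=O` gives 290 nM in this assay.

Compound 3 differs from compound 1 by acetyl in place of hydrogen on a nitrogen on an aromatic ring. This step is a 1.6-fold lower number from compound 1 to compound 3 (0.19 log units; within the scatter), so the two numbers cannot be told apart with confidence. Compound 2 is built on a different core from compound 1; the difference between the two cores is not broken down here. Compound 4 `CCCSc1nc(NC(C)=O)c(N(CCC)CCC)c(OCC)n1` has not yet been measured. Going by the values given here, it differs from compound 2 by acetyl in place of hydrogen on a nitrogen on an aromatic ring, the same change as the one from compound 1 to compound 3. The expectation for compound 4 rests on that single earlier step only, so a similarly small step is expected, a 1.4-fold lower number from compound 2 to compound 4 (0.13 log units; within the scatter). Compound 4 is therefore estimated at 110 nM in this assay, with a likely range from 50 nM to 260 nM.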

Compound 4, half-maximal effective concentration: 1000 nM
Beside the measured number, compound 4's estimate is 9.1-fold (0.96 log units) below it; the whole stated range lies below it.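

Setting acetyl in place of hydrogen on a nitrogen on an aromatic ring gives a 6.7-fold higher number from compound 2 to compound 4 (0.82 log units; beyond the scatter) in this assay. The same change therefore does not carry over with the same effect from the core of compound 1 to the core of compound 2, as the two steps show when set side by side: the same change on two cores in this assay, a 1.6-fold lower number (0.19 log units; within the scatter) from compound 1 to compound 3 and a 6.7-fold higher number (0.82 log units; beyond the scatter) from compound 2 to compound 4, 10-fold (1.01 log units) apart, beyond the scatter of two such steps

With a single pair on each core, this does not show which feature of the cores sets the two steps apart, and it gives no general rule for the series. The compounds shown leave open how a methyl group or a longer acyl chain such as butanoyl on this nitrogen would behave on either core. On these data alone, it also remains open which single part of the core decides the size and direction of the step.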